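Dropping One Methoxy from a Weakly Cytotoxic Oxazole

The compounds below may be only part of what the source reports. "The series", "measured", "known", "first", "only" and "open" are said of these compounds alone.

Measured compounds:
compound 1 `COc1ccc(-c2nc(-c3c[nH]c4ccccc34)co2)cc1OC`: 103000 nM
compound 2 `C(=C/c1nc(-c2c[nH]c3ccccc23)co1)\c1ccccc1`: 103000 nM

In a functional assay on MDA-MB-231 cells (Homo sapiens) for cytotoxicity, read by MTT assay, with a stated time of 48 h (on this read-out higher numbers stand for weaker inhibition and lower numbers for stronger inhibition), compound 1 gives 103000 nM, and compound 2 gives 103000 nM, so compound 1 stands level with compound 2 within the scatter. Compound 3 `COc1ccc(-c2nc(-c3c[nH]c4ccccc34)co2)cc1` is not yet measured. It differs from compound 1 by hydrogen in place of methoxy on an aromatic carbon. Among the compounds with values here, with no measured step to guide the size, compound 3 is expected to stay close to compound 1, with a step of a 1.0-fold lower number from compound 1 to compound 3 (0.01 log units; within the scatter) of no more than the scatter in either direction. Compound 3 is therefore estimated at 100000 nM, with a range from 40000 nM to 250000 nM.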

Compound 3, half-maximal inhibitory concentration: 108000 nM
The estimate for compound 3 lay 1.1-fold (0.03 log units) below the measured number; measured number inside the range.
By their numbers in this assay, from the lowest: compounds 1, 2 and 3 (each within the scatter of the next).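

In this assay, hydrogen in place of methoxy on an aromatic carbon, ortho to a methoxy group and meta to a large group, gives a 1.0-fold higher number from compound 1 to compound 3 (0.02 log units; within the scatter). At this position, then, methoxy and hydrogen read alike, so this methoxy is not needed to hold the level of compound 1. Still open, as far as these compounds go, is whether an amine, a carboxylic acid or a longer chain at this position would read differently, and whether losing the methoxy that remains in compound 3 would matter. No measurement at hand bears on this result.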